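The compounds below may be only part of what the source reports. "The series", "measured", "known", "first", "only" and "open" are said of these compounds alone.

Working notes on the series in a functional assay on HCT-116 cells (Homo sapiens) for inhibition, read by sulforhodamine B assay, with a stated time of 48 h; on this read-out lower numbers stand for stronger inhibition of growth and higher numbers for weaker inhibition of growth. Compound 1 `COc1cc(-c2nn(-c3cccc(NC(=O)c4cccc(C(F)(F)F)c4)c3)cc2-c2ccncc2)ccc1Cl` gives > 50000 nM, which is a limit of the assay rather than a number. Compound 2 `COc1cc(-c2nn(-c3cccc(NC(=O)Nc4ccc(Cl)c(Cl)c4)c3)cc2-c2ccncc2)ccc1Cl` likewise gives only a limit, > 50000 nM. Compound 3 `COc1cc(-c2nn(-c3cccc(NC(=O)c4ccc(Cl)c(C(F)(F)F)c4)c3)cc2-c2ccncc2)ccc1Cl` also stops at a limit, > 32500 nM, so it stands at the limit of > 32500 nM in this assay, at which 1 of the 3 values shown sits, whereas the other two values sit at the limit of > 50000 nM in this assay, at which 2 of the 3 values shown sit. The steps a step that the two limits leave unreadable from compound 1 to compound 2, a step that the two limits leave unreadable from compound 1 to compound 3 and a step that the two limits leave unreadable from compound 2 to compound 3 cannot be given a size for that reason. Compound 4 `COc1cc(-c2nn(-c3cccc(NC(=O)Nc4ccc(Cl)c(C(F)(F)F)c4)c3)cc2-c2ccncc2)ccc1Cl` differs from compound 3 by (4-chloro-3-(trifluoromethyl)phenyl)amino in place of 4-chloro-3-(trifluoromethyl)phenyl on a carbonyl carbon. Among the measured compounds shown here, none of the measured steps yields a readable size, so no change beyond the scatter is expected here. Compound 4 is therefore expected at 60000 nM (from 30000 nM to 150000 nM), an expected step that the limit leaves unreadable from compound 3 to compound 4, most likely reported again only as a limit.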

Compound 4, concentration for total growth inhibition: 4560 nM
The estimate for compound 4 lay 13-fold (1.12 log units) above the measured number, outside the stated range (below it).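

In this assay, among the compounds shown here, (4-chloro-3-(trifluoromethyl)phenyl)amino on the carbonyl carbon gives the first readable number, with an at least 7.1-fold lower number from compound 3 to compound 4 (0.85 log units; beyond the scatter), and the same group in place of 3-(trifluoromethyl)phenyl gives an at least 10-fold lower number from compound 1 to compound 4 (1.04 log units; beyond the scatter). Trifluoromethyl in place of chloro on an aromatic carbon also matters, with an at least 10-fold lower number from compound 2 to compound 4 (1.04 log units; beyond the scatter), so among these compounds neither the amino link nor the trifluoromethyl group alone gives a readable number. The step from compound 3 rests on a limit, not a number: the limit of > 32500 nM in this assay, at which 1 of the 4 values shown sits.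

Going by these compounds, the true sizes of all three steps remain open, as do the values of compound 1, compound 2 and compound 3. On these data alone, it is also open whether a nitrile or a methyl in place of trifluoromethyl would keep the effect.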